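Working notes: chloro in place of hydrogen on the phenyl group

The source may hold more compounds than are shown below. What is called first, only, known or untested is meant among the compounds shown, and "the series" means these compounds.

Measured so far:
compound 1, `Cc1nc(-c2ccccc2)sc1COc1ccc2c(c1)OCC2CC(=O)O`: 54.8%
compound 2, `O=C(O)CC1COc2cc(OCc3csc(-c4ccccc4)n3)ccc21`: 0.15%

In a functional assay on CHO cells for agonist activity at Free fatty acid receptor 1 (Homo sapiens), read by FLIPR and calcium flux, tested at 100 nM (on this read-out lower numbers stand for a weaker effect and higher numbers for a stronger effect at the one concentration tested), compound 1 gives 54.8%, the highest of the two numbers shown. Compound 2 gives 0.15%, a number far lower, beyond the scatter; no single-change comparison between these two is set out, so only their two values are noted. Compound 3, `Cc1nc(-c2ccccc2Cl)sc1COc1ccc2c(c1)OCC2CC(=O)O`, has not been measured. It differs from compound 1 by chloro in place of hydrogen on an aromatic carbon. Among the compounds with values here, no measured pair carries this change, so the numbers themselves give no guide to its size, and the reading of compound 1 is the only anchor. A step of a number 0.2 percentage points higher from compound 1 to compound 3 (within the scatter) is expected, that is, nothing beyond the scatter, with either direction open. For compound 3 the estimate is 55%, expected to fall between 30% and 80%.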

Compound 3, a percentage reported as activity, at one concentration (the size of the read-out at that concentration, not a potency): 12.4%
Estimate against measurement, compound 3: 42.6 percentage points above, and the stated range ends above it.
By their numbers in this assay, from the lowest: compound 2; then compound 3; then compound 1.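

In this assay the change from phenyl to 2-chlorophenyl, chloro in place of hydrogen, is a number 42.4 percentage points lower from compound 1 to compound 3 (beyond the scatter). Within the data shown here, this is the first reading on a substituent at this place on the phenyl group, and it shows that the place is not indifferent: one chlorine atom removes much of the effect at the one concentration tested, though compound 3 still gives 12.4% rather than nothing. Nothing measured here accounts for the loss.

Among these compounds, the single change leaves open whether the loss belongs to chloro itself or would also follow from fluoro, methyl or methoxy on the same carbon. It also leaves open whether chloro on another carbon of the phenyl group would be tolerated on the core of compound 1.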